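The source may report more compounds than this note shows. Statements on the series, on what has been measured and on what is new or still open speak of the compounds shown alone.

Of the compounds shown here, three of a shared core have been measured in a physicochemical assay for solubility, read by HPLC, using the shake flask method, measured as kinetic solubility, with a stated time of 2 h, at pH 7.4; on this read-out higher numbers stand for higher solubility and lower numbers for lower solubility. Compound 1 `Cc1cc(NCc2ncccn2)n2nc(C)c(-c3ccccc3)c2n1` gives 37900 nM. Compound 2 `Cc1cc(NCc2ccccn2)n2ncc(-c3ccccc3F)c2n1` gives 5000 nM. Compound 3 `Cc1cc(NCc2ccccn2)n2nc(C)c(Nc3ccccc3)c2n1` gives 7800 nM. Among these three numbers, compound 2 stands lowest: its nearest neighbour is compound 3, whose number lies within the usual scatter of the one for compound 2, so no order can be read between those two; compound 1, at the far end, lies beyond the scatter, so compound 2 is clearly less soluble than compound 1 in this assay.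

The step now followed leads from compound 2 to compound 4 `Cc1cc(NCc2ccccn2)n2ncc(C3=CCC(F)(F)CC3)c2n1`, which has not yet been measured. The change between the two is a single one, at the aromatic carbon of the five-membered ring with two nitrogens in the fused system: 4,4-difluorocyclohex-1-en-1-yl in place of 2-fluorophenyl on an aromatic carbon.

For the measured compounds named here, no measured pair in this set shows the same change, so any expectation rests on the three numbers alone and on the nature of the swap. A modest rise is expected, in the step of a 2.0-fold higher number from compound 2 to compound 4 (0.30 log units; within the scatter), though a result within the scatter would not surprise. Compound 4 is therefore estimated at 10000 nM, with a range from 3000 nM to 35000 nM in this assay.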

Compound 4, solubility: 5000 nM
Compound 4: the middle estimate sits 2.0-fold (0.30 log units) above what was measured; the measured number falls inside the stated range.
By their numbers in this assay, from the lowest: compounds 2, 4 and 3 (each within the scatter of the next); then compound 1.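

For the compounds shown here, at the aromatic carbon of the five-membered aromatic ring with 2 nitrogen, this assay gives no change at the digits printed from compound 2 to compound 4 (within the scatter) when 4,4-difluorocyclohex-1-en-1-yl takes the place of 2-fluorophenyl, and this is the only comparison in the set in which a single place differs. At this position, then, a six-membered aromatic ring of carbon only gave way to a six-membered non-aromatic ring of carbon only, with a double bond outside aromatic rings and a second fluorine, and the read-out did not leave the scatter. Nothing available here accounts for this outcome, and it rests on one pair of compounds.

Still open, on these data alone, is whether a group of another kind at this carbon, such as a saturated ring carrying an amine or a carboxylic acid, would give a step beyond the scatter in this assay. As far as these compounds go, compound 1 and compound 3 each differ from compound 2 in more than one place, so they give no reading of any single change, and whether the swap seen here would behave the same way on their frameworks also remains open.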